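The source may hold more compounds than are shown below. What is called first, only, known or untested is meant among the compounds shown, and "the series" means these compounds.

Measured so far in a functional assay on T47D cells (Homo sapiens) for antiproliferative activity, read by sulforhodamine B assay, with a stated time of 48 h; on this read-out higher numbers stand for weaker inhibition of growth and lower numbers for stronger inhibition of growth:
compound 1 `Nc1nn(C(=O)Nc2ccc(Cc3ccccc3)cc2)c2ccccc12`: 1550 nM
compound 2 `Nc1nn(C(=O)Nc2ccc(Cc3ccccc3)cc2)c2ccc(Cl)cc12`: 74.1 nM

Within the data shown here, compound 2 holds the lower of the two numbers; its only neighbour is compound 1, and the step of a 21-fold lower number from compound 1 to compound 2 (1.32 log units; beyond the scatter) lies beyond the scatter. Compound 3 `Nc1ccc2c(c1)c(N)nn2C(=O)Nc1ccc(Cc2ccccc2)cc1` is not yet measured. Its change from compound 2 is amino in place of chloro on an aromatic carbon. Among the measured compounds shown here, the one measured step at the same aromatic carbon, a 21-fold lower number from compound 1 to compound 2 (1.32 log units; beyond the scatter), shows that what sits there can move this read-out a great deal, but it compares chloro with hydrogen, not chloro with amino; no measured compound carries amino at that place, so the direction of the new step is not fixed by the data. The working expectation is a number between the two measured values, with a wide range covering both. Compound 3 is estimated at 400 nM (range 80 nM to 2500 nM), an expected step of a 5.4-fold higher number from compound 2 to compound 3 (0.73 log units; beyond the scatter).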

Compound 3, concentration for 50% growth inhibition: 5800 nM
Beside the measured number, compound 3's estimate is 15-fold (1.16 log units) below it, outside the stated range (above it).
By their numbers in this assay, from the lowest: compound 2; then compound 1; then compound 3.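

In this assay, amino in place of chloro on this aromatic carbon gives a 78-fold higher number from compound 2 to compound 3 (1.89 log units; beyond the scatter), so the gain seen with chloro does not carry over to amino. Set against the unsubstituted compound, amino gives a 3.7-fold higher number from compound 1 to compound 3 (0.57 log units; beyond the scatter) while chloro gives a 21-fold lower number from compound 1 to compound 2 (1.32 log units; beyond the scatter): the two groups move the read-out in opposite directions from hydrogen, so this place can both strengthen and weaken inhibition of growth, depending on the group it carries. Nothing at hand explains this difference between chloro and amino.

The compounds shown leave open whether the strong value belongs to chloro alone or extends to fluoro, bromo, methyl or nitrile at the same carbon. They also leave open whether an acetylated amino group would behave like amino itself.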